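This account rests on a few compounds, and the source may have more. Where it says the series, first, only, none or still open, it means among the compounds named here.

Measured compounds:
- compound 1, `COc1ccccc1C1C(C(=O)C(C)(C)C)=C(O)C(=O)N1c1ccc(-c2ccon2)cc1`: 0.002
- compound 2, `Cc1cc(-c2ccc(N3C(=O)C(O)=C(C(=O)C(C)(C)C)C3c3ccccc3OCCO)cc2)on1`: "not determined" (no result reported)

Among the compounds with values here, compound 1 is the only compound with a number in an ADME assay on the whole organism (serum, Rattus norvegicus) for protein binding; on this read-out lower numbers stand for a smaller free fraction and higher numbers for a larger free fraction; here compound 1 gives 0.002. Compound 2, `Cc1cc(-c2ccc(N3C(=O)C(O)=C(C(=O)C(C)(C)C)C3c3ccccc3OCCO)cc2)on1`, shares the same core but in this assay compound 2 gives "not determined" (no result reported), so it stands nowhere on the numbers shown: there is no value to place it against compound 1, and no step between the two is given.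

Compound 3, `CC(C)(C)C(=O)C1=C(O)C(=O)N(c2ccc(-c3ccsc3)cc2)C1c1ccccc1OCCO`, has not been measured yet. It differs from compound 2 in one place: thiophen-3-yl in place of 3-methyl-1,2-oxazol-5-yl on an aromatic carbon. Within the data shown here, no measured pair shows a change of this kind, so there is nothing in the data that says how this assay answers it. Among the measured compounds shown here, with no comparable step on record, the expectation for this assay is a change of no size beyond the usual scatter, in no particular direction, and the only anchor is the single number of compound 1.

For compound 3 the unbound fraction in this assay is therefore expected near 0.002, with a likely range from 0.0007 to 0.006.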

Compound 3, unbound fraction: 0.002
Compound 3: the middle estimate sits on the measured number at the digits printed; measured number inside the range.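

No new step can be read in this assay: compound 2 offers no number to set against compound 3, its neighbour differing in one place. No data shown here bear on this result. The compounds shown leave open how replacing 3-methyl-1,2-oxazol-5-yl with thiophen-3-yl affects the unbound fraction.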